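A few compounds are considered here, and "the series" means these few. Any claim that something is new, unique, unknown or untested is made for them only; others in the source may bear on it.

Within the data shown here, in a functional assay (trachea) with Cavia porcellus as the target (a lower number here means a stronger inhibitor, a higher number a weaker inhibitor), compound 2 `CC(=O)OCCn1nc(-c2cccnc2)c2ccccc2c1=O` gives 9770 nM and holds the higher of the two numbers so far, which makes it the weaker inhibitor of the pair. Compound 1 `CC(C)=CCn1nc(-c2cccnc2)c2ccccc2c1=O` gives 1380 nM on the same shared core. Compound 3 `O=c1c2ccccc2c(-c2cccnc2)nn1CCSc1ccccc1` is compound 2 with one group exchanged: phenylsulfanyl in place of acetoxy on a saturated chain carbon, two bonds along the chain from an aromatic nitrogen on a saturated chain carbon, two bonds along the chain from an aromatic nitrogen. Among the measured compounds shown here, only one measured step bears on this, namely a 7.1-fold higher number from compound 1 to compound 2 (0.85 log units; beyond the scatter) and it is modest but beyond the scatter. For the measured compounds named here, that step also replaces the end of this chain, though with a different group, and no measured compound carries phenylsulfanyl, so it is only a rough guide. Losing the acetoxy group is expected to recover part of that step in this assay rather than all of it. The expected change is a 3.3-fold lower number from compound 2 to compound 3 (0.51 log units; beyond the scatter) as a rough estimate, towards a lower number. For compound 3 the estimated value is 3000 nM (expected range 700 nM to 12000 nM).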

Compound 3, half-maximal inhibitory concentration: 9120 nM
Estimate against measurement, compound 3: 3.0-fold (0.48 log units) below; the measured number falls inside the stated range.
By their numbers in this assay, from the lowest: compound 1; then compounds 3 and 2 (each within the scatter of the next).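

In this assay, phenylsulfanyl in place of acetoxy gives a 1.1-fold lower number from compound 2 to compound 3 (0.03 log units; within the scatter), so at this place on the chain, an end group with a six-membered aromatic ring of carbon only reads the same as one with no ring. Compound 1 still stands apart, with a 6.6-fold higher number from compound 1 to compound 3 (0.82 log units; beyond the scatter), so the gap first seen with acetoxy also appears with a very different end group, and among these three compounds it is the 2-methylprop-1-en-1-yl compound that differs from the other two. No measurement shown here explains this result.

From the compounds shown here alone, it remains open whether another end group on this chain, such as an amine or a carboxylic acid, would match compound 1 or improve on it. Going by these compounds, it is equally open whether a longer chain would change the number.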